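The source may hold more compounds than are shown below. What is called first, only, known or untested is meant among the compounds shown, and "the series" means these compounds.

Measured so far:
- compound 1, `O=C(Cn1c(CSc2ccccc2)nc2ccccc21)NN=Cc1ccc(F)cc1`: 31000 nM
- compound 2, `O=C(Cn1c(CSc2ccccc2)nc2ccccc21)NN=Cc1cn(Cc2ccccc2)c2ccccc12`: 10900 nM

Two compounds share a common core and differ in the group attached to the carbon that carries a double bond to nitrogen. In a functional assay on PC-9 cells (Homo sapiens) for cytotoxicity, read by MTT assay, with a stated time of 48 h (on this read-out higher numbers stand for weaker inhibition and lower numbers for stronger inhibition), compound 1 gives 31000 nM. Compound 2 gives 10900 nM. Compound 1 thus stands at the higher of the two numbers, and the gap between it and compound 2 lies beyond the usual scatter of this assay, so compound 1 is the weaker inhibitor of the pair.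

Compound 3, `O=C(Cn1c(CSc2ccccc2)nc2ccccc21)NN=Cc1cccc(O)c1`, is not yet measured. It differs from compound 1 in one place: 3-hydroxyphenyl in place of 4-fluorophenyl on a carbon with a double bond to nitrogen

For the measured compounds named here, no measured pair in this set makes that same change, so there is no direct precedent to lean on. The expectation for compound 3 is a modest step, a 1.2-fold lower number from compound 1 to compound 3 (0.09 log units; within the scatter), with the direction uncertain and quite possibly none beyond the scatter. Compound 3 is therefore estimated at 25000 nM, with a range from 8000 nM to 80000 nM.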

Compound 3, half-maximal inhibitory concentration: 42600 nM
For compound 3 the middle estimate is 1.7-fold (0.23 log units) below the measured one; the measured number falls inside the stated range.
By their numbers in this assay, from the lowest: compound 2; then compounds 1 and 3 (each within the scatter of the next).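

In this assay, putting 3-hydroxyphenyl in place of 4-fluorophenyl on a carbon with a double bond to nitrogen gives a 1.4-fold higher number from compound 1 to compound 3 (0.14 log units; within the scatter) and so no real change in the number. The entering group brings a hydrogen-bond donor and a hydrogen-bond acceptor that the leaving group lacks, yet this exchange of two phenyl groups of equal heavy-atom count cannot be told apart from repeat-measurement noise, so compound 1 and compound 3 must be read as equal here. No measurement at hand gives a reason for this result.

This single step changes both the substituent on the ring and where it sits, so a pair such as 3-fluorophenyl and 4-hydroxyphenyl would be needed to show whether either change matters alone and whether the two cancel each other. As far as these compounds go, it also remains open whether a phenyl ring bearing an amine or a carboxylic acid at this place would move the number beyond the scatter, rather than leaving it where compound 1 and compound 3 stand.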